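Swapping a tert-butyl for a 2-chlorophenyl on the ether oxygen

A few compounds are considered here, and "the series" means these few. Any claim that something is new, unique, unknown or untested is made for them only; others in the source may bear on it.

Of the compounds shown here, three sharing one core have been measured in a functional assay for inhibition of sodium/hydrogen exchanger (Oryctolagus cuniculus); a higher number here means a weaker inhibitor, a lower number a stronger inhibitor. Compound 1 `Cc1cc(Sc2ccccc2Cl)c(S(C)(=O)=O)cc1C(=O)N=C(N)N` gives 14 nM. Compound 2 `CCOc1cc(C)c(C(=O)N=C(N)N)cc1S(C)(=O)=O` gives 19 nM. Compound 3 `Cc1cc(OC(C)(C)C)c(S(C)(=O)=O)cc1C(=O)N=C(N)N` gives 9.4 nM, the lowest number of the three, although its gap to compound 1 lies within the scatter; the step of a 1.5-fold lower number from compound 1 to compound 3 (0.17 log units; within the scatter) is small, while the step of a 2.0-fold lower number from compound 2 to compound 3 (0.31 log units; beyond the scatter) is modest but real.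

Compound 4 `Cc1cc(Oc2ccccc2Cl)c(S(C)(=O)=O)cc1C(=O)N=C(N)N` differs from compound 3 in one place: 2-chlorophenyl in place of tert-butyl on an oxygen on an aromatic ring. Among the measured compounds shown here, two measured steps bear on this. Replacing the (2-chlorophenyl)sulfanyl group of compound 1 by tert-butoxy gave only a 1.5-fold lower number from compound 1 to compound 3 (0.17 log units; within the scatter), and lengthening the ether from ethyl to tert-butyl gave a 2.0-fold lower number from compound 2 to compound 3 (0.31 log units; beyond the scatter). Compound 4 carries the same 2-chlorophenyl as compound 1, now on an oxygen, so its number is expected to sit near compound 1 and compound 3, with the step of a 1.4-fold higher number from compound 3 to compound 4 (0.14 log units; within the scatter) expected to stay within the scatter. Compound 4 is estimated at 13 nM, in the range 6 nM to 28 nM in this assay.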

Compound 4, half-maximal inhibitory concentration: 14 nM
The estimate for compound 4 lay 1.1-fold (0.03 log units) below the measured number; the measured number falls inside the stated range.
By their numbers in this assay, from the lowest: compounds 3, 1, 4 and 2 (each within the scatter of the next, the first and the last beyond it).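

In this assay, putting 2-chlorophenyl on the oxygen in place of tert-butyl gives a 1.5-fold higher number from compound 3 to compound 4 (0.17 log units; within the scatter), and putting it in place of ethyl gives a 1.4-fold lower number from compound 2 to compound 4 (0.13 log units; within the scatter), so on this oxygen a six-membered aromatic ring reads no differently from either open-chain group. The linking atom also makes no visible difference: 2-chlorophenoxy in place of (2-chlorophenyl)sulfanyl gives no change at the digits printed from compound 1 to compound 4 (within the scatter), which means that oxygen and sulfur carrying the same ring cannot be told apart in this assay. No measurement shown here offers a reason for why such different groups read alike.

On these data alone, it remains open whether a plain phenyl without the chlorine would read the same on this oxygen. As far as these compounds go, it is equally open whether an amine or a carboxylic acid at the end of a longer chain would keep the number in this range.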